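Changing the Aryl Group on an Aromatic Nitrogen

This account rests on a few compounds, and the source may have more. Where it says the series, first, only, none or still open, it means among the compounds named here.

Compound 1 `N#CC1=C(N)Oc2c(c3nc4ccccc4nc3c3ccccc23)C12C(=O)N(Cc1cnnn1-c1ccc(F)cc1)c1ccccc12` is tested in a functional assay on A549 cells (Homo sapiens) for antiproliferative activity, read by MTT assay, with a stated time of 48 h; a higher number here means a weaker inhibitor, a lower number a stronger inhibitor. In this assay compound 1 gives only a limit, > 50000 nM, so its standing among the numbers is not fixed; it sits at the weak end of what the assay reports. Compound 2 `N#CC1=C(N)Oc2c(c3nc4ccccc4nc3c3ccccc23)C12C(=O)N(Cc1cnnn1-c1cccc(S(N)(=O)=O)c1)c1ccccc12`, which carries a 3-sulfamoylphenyl in place of the 4-fluorophenyl on the aromatic nitrogen, gives 44200 nM in this assay. Among the compounds with values here, the step of an at least 1.1-fold lower number from compound 1 to compound 2 (0.05 log units; that floor lies within the scatter) is the only measured step, and its size rests on (the limit of > 50000 nM in this assay, at which 1 of the 2 values shown sits), so it shows no more than that both compounds lie at or near the weak end.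

Compound 3 `N#CC1=C(N)Oc2c(c3nc4ccccc4nc3c3ccccc23)C12C(=O)N(Cc1cnnn1-c1cc(Cl)ccc1Cl)c1ccccc12` is not yet measured. It differs from compound 1 by 2,5-dichlorophenyl in place of 4-fluorophenyl on an aromatic nitrogen. Within the data shown here, the one measured step bears on it only loosely: a change of the aryl group on the same nitrogen did not move the number beyond the scatter, and compound 1 sits at a limit. Compound 3 is therefore expected to give a number near that limit, with the step of a number no higher from compound 1 to compound 3 (the limit leaves the size open) not beyond the scatter. The estimate for compound 3 in this assay is 50000 nM, within the range 20000 nM to 150000 nM.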

Compound 3, half-maximal inhibitory concentration: > 50000 nM
Compound 3 ended at the assay's limit; the forecaster's own chance of this, stated with the estimate: 65%; the middle value lies on the limit itself.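

Compound 3 adds a second aryl group, 2,5-dichlorophenyl, that stays at the weak end of this assay, so replacing 4-fluorophenyl on this aromatic nitrogen with an aryl group carrying two chlorine atoms gave no sign of a stronger inhibitor. The step between compound 1 and compound 3 cannot be read, as both values are limits of the assay and not numbers. The one readable new comparison is an at least 1.1-fold higher number from compound 2 to compound 3 (0.05 log units; that floor lies within the scatter), so across the three aryl groups at this position nothing yet stands beyond the scatter, and the data resolve little here: the limit of > 50000 nM in this assay, at which 2 of the 3 values shown sit.

The compounds shown leave open whether a phenyl group bearing an amine or a carboxylic acid, or a longer alkyl chain in place of the aryl group, would bring the number clearly under the limit. They also leave open how far compound 1 and compound 3 lie past the limit, and whether the true values of these two compounds differ at all.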